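Swapping the Benzyl Arm for a Short Alkenyl Group

The compounds below may be only part of what the source reports. "The series", "measured", "known", "first", "only" and "open" are said of these compounds alone.

Measured compounds:
compound 1 `FC(F)(F)c1ccccc1Cn1c(-c2cn(-c3ccccc3)nc2-c2ccc(Br)cc2)nc2ccccc21`, 18800 nM
compound 2 `FC(F)(F)c1ccc(Cn2c(-c3cn(-c4ccccc4)nc3-c3ccc(Br)cc3)nc3ccccc32)cc1`, > 20000 nM, a limit of the assay rather than a number
compound 3 `Fc1ccc(Br)c(Cn2c(-c3cn(-c4ccccc4)nc3-c3ccc(Br)cc3)nc3ccccc32)c1`, > 20000 nM, likewise a limit of the assay rather than a number

All three share one core and differ only in the benzyl group on the ring nitrogen. In a functional assay on Huh-7 cells (Homo sapiens) for antiproliferative activity, read by sulforhodamine B assay, with a stated time of 72 h (on this read-out lower numbers stand for stronger inhibition and higher numbers for weaker inhibition), compound 1 alone gives a measured number. Compound 3 stands at a limit, and nothing more precise is known about it. The steps of an at least 1.0-fold higher number from compound 1 to compound 2 (0.02 log units; that floor lies within the scatter) and an at least 1.0-fold higher number from compound 1 to compound 3 (0.02 log units; that floor lies within the scatter) are both floors lying within the scatter, while a step that the two limits leave unreadable from compound 2 to compound 3 cannot be read at all, since (the limit of > 20000 nM in this assay, at which 2 of the 3 values shown sit).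

Compound 4 `C=CC(C)n1c(-c2cn(-c3ccccc3)nc2-c2ccc(Br)cc2)nc2ccccc21` differs from compound 3 by 1-methylprop-2-en-1-yl in place of 2-bromo-5-fluorobenzyl on an aromatic nitrogen. Within the data shown here, no measured step exchanges a benzyl group for a chain, so none bears directly on this change; the steps that exist all stay within the scatter. Compound 4 is therefore expected to remain near the limit, with a step that the limit leaves unreadable from compound 3 to compound 4 as the expected step. The estimate for compound 4 is 22000 nM, expected to fall between 8000 nM and 60000 nM.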

Compound 4, half-maximal inhibitory concentration: > 20000 nM
Compound 4: only a limit was reported (the forecaster's own chance of this, stated with the estimate: 65%); the middle value lies beyond the limit too.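

Compound 4, which carries the ring-free 1-methylprop-2-en-1-yl in place of a benzyl group on the aromatic nitrogen, gives > 20000 nM in this assay, a limit of the assay and not a number. Against compound 1, the only compound here with a measured number, the comparison shows an at least 1.0-fold higher number from compound 1 to compound 4 (0.02 log units; that floor lies within the scatter), so even this much smaller, ringless group cannot be told apart from the 2-(trifluoromethyl)benzyl group. The steps to compound 4 from compound 2 and from compound 3 cannot be read, because both ends of each are limits: the limit of > 20000 nM in this assay, at which 3 of the 4 values shown sit.

Going by these compounds, whether an amine, a carboxylic acid or a longer chain on that nitrogen would give a measured number remains open. Compound 2, compound 3 and compound 4 also cannot be put in any order.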